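From a dimethylamino chain to an oxolane ring

The source may hold more compounds than are shown below. What is called first, only, known or untested is meant among the compounds shown, and "the series" means these compounds.

Compound 1 (`COc1cc(CNCCCN(C)C)ccc1OCc1ccc(Cl)nc1`) gives 5000 nM
Compound 2 (`COc1cc(CNCc2ccncc2)ccc1OCc1ccc(Cl)cc1`) gives 890 nM

In a functional assay on HeLa cells (Homo sapiens) for inhibition, with a stated time of 72 h (on this read-out higher numbers stand for an effect only at larger amounts of compound and lower numbers for an effect already at smaller amounts), compound 1 has the higher number of the two, at 5000 nM against 890 nM for compound 2 (a gap beyond the scatter). Compound 3 (`COc1cc(CNCC2CCCO2)ccc1OCc1ccc(Cl)nc1`) keeps the core of compound 1 but carries oxolan-2-yl in place of 2-(dimethylamino)ethyl on a saturated chain carbon bound to an amine nitrogen. Among the compounds with values here, no measured pair differs in one place, so the expectation remains loose. A modest step towards a lower number is expected in this assay (a 1.7-fold lower number from compound 1 to compound 3 (0.22 log units; within the scatter)) for this change. The estimated value for compound 3 is 3000 nM (expected range 1000 nM to 10000 nM) in this read-out.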

Compound 3, half-maximal effective concentration: 66000 nM
Beside the measured number, compound 3's estimate is 22-fold (1.34 log units) below it; the measured number lies above the stated range.
By their numbers in this assay, from the lowest: compound 2; then compound 1; then compound 3.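

In this assay the change from 2-(dimethylamino)ethyl to oxolan-2-yl on a saturated chain carbon bound to an amine nitrogen gives a 13-fold higher number from compound 1 to compound 3 (1.12 log units; beyond the scatter) and so counts as a large step. This position is therefore sensitive to the group it carries, even though the heavy-atom and hydrogen-bond acceptor counts stay the same. Nothing at hand gives a reason for this step. The compounds shown leave open whether the step follows the entering ring or the departing dimethylamino nitrogen. An open 2-methoxyethyl chain and a pyrrolidin-2-yl ring would separate these two readings.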